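Piperidine replaces thiomorpholine on the thiocarbonyl carbon

The source may hold more compounds than are shown below. What is called first, only, known or untested is meant among the compounds shown, and "the series" means these compounds.

Among the compounds with values here, compound 2 `N/C(=N\NC(=S)N1CCSCC1)c1ccccn1` stands lowest of the two numbers so far: in a functional assay on MCF7 cells (Homo sapiens) for cytotoxicity, read by MTT assay, with a stated time of 72 h, tested at 10 uM (a higher number here means more inhibition of growth at the concentration tested, a lower number less inhibition of growth), compound 2 gives 54.3%, whereas compound 1 `N/C(=N\NC(=S)N1CCOCC1)c1ccccn1` gives 66.7%. Within the data shown here, the only measured step is a number 12.4 percentage points lower from compound 1 to compound 2 (beyond the scatter), which also alters the ring on the thiocarbonyl carbon. Compound 3 `N/C(=N\NC(=S)N1CCCCC1)c1ccccn1` is not yet measured; it carries piperidin-1-yl in place of thiomorpholin-4-yl on a thiocarbonyl carbon, a change that the measured step covers only loosely. Since that step was modest and not a direct precedent, no change beyond the scatter is expected for compound 3, estimated at 52% with a range from 35% to 70%. The expected step is a number 2.3 percentage points lower from compound 2 to compound 3 (within the scatter).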

Compound 3, percent growth inhibition at one concentration: 53.1%
Estimate against measurement, compound 3: 1.1 percentage points below; low and high end bracket the measured number.
By their numbers in this assay, from the lowest: compounds 3 and 2 (each within the scatter of the next); then compound 1.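

In this assay, piperidin-1-yl and thiomorpholin-4-yl on the thiocarbonyl carbon give matching numbers, with a number 1.2 percentage points lower from compound 2 to compound 3 (within the scatter). Morpholin-4-yl remains apart, with a number 13.6 percentage points lower from compound 1 to compound 3 (beyond the scatter), so among these three rings the gap to compound 1 does not depend on a ring sulfur. Nothing on hand accounts for that gap. Still open, from the compounds shown here alone, is how a piperazin-1-yl ring or an open-chain dimethylamino group on the thiocarbonyl carbon would compare with compound 1.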